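The source may hold more compounds than are shown below. What is called first, only, known or untested is meant among the compounds shown, and "the series" means these compounds.

Measured compounds:
- compound 1, `O=c1cc(-c2ccccc2)oc2cc(N3COc4c(cccc4[N+](=O)[O-])C3)ccc12`: "not active" (no number reported)
- compound 2, `O=c1cc(-c2ccccc2)oc2cc(N3COc4c(Br)cccc4C3)ccc12`: 2.21%

In a functional assay on MCF7 cells (Homo sapiens) for inhibition, read by MTT assay, with a stated time of 48 h, tested at 7.5 ug/mL (on this read-out higher numbers stand for more inhibition of growth at the one concentration tested and lower numbers for less inhibition of growth), compound 2 gives 2.21%, the only number shown; compound 1 gives no number and is simply called inactive, so compound 2 cannot be ranked against it. Compound 3, `O=c1cc(-c2ccccc2)oc2cc(N3COc4c(Br)cc(Br)cc4C3)ccc12`, differs from compound 2 by bromo in place of hydrogen on an aromatic carbon. Among the compounds with values here, no measured pair shows what such a change does here, so no step beyond the usual scatter is expected in this assay. Compound 3 is therefore estimated at 5%, within 0% to 20%, an expected step of a number 2.8 percentage points higher from compound 2 to compound 3 (within the scatter).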

Compound 3, percent growth inhibition at one concentration: 1.48%
Compound 3: the middle estimate sits 3.5 percentage points above what was measured, and the stated range covers the measured number.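

Adding a second bromo group, meta to the existing bromo group, gives the first readable step in this series: in this assay there is a number 0.7 percentage points lower from compound 2 to compound 3 (within the scatter) at this position. This one change therefore does not separate the two compounds, and a second bromo brings no measurable gain in growth inhibition. No measurement shown here explains this result.

As far as these compounds go, whether an amine, a carboxylic acid or a longer chain at this same carbon would move the read-out remains open. A single bromo swap cannot show how other groups behave here.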